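A Second Methoxy Group on the Benzyl Arm

A few compounds are considered here, and "the series" means these few. Any claim that something is new, unique, unknown or untested is made for them only; others in the source may bear on it.

Of the compounds shown here, three sharing one core have been tested in a functional assay on NCI-H1299 cells (Homo sapiens) for antiproliferative activity, read by fluorescence and resazurin assay, with a stated time of 48 h; a higher number here means a weaker inhibitor, a lower number a stronger inhibitor. Compound 1 `COc1ccc(Cn2cc(-c3ccc(O)cc3)c(-c3ccc(O)cc3)c2)cc1` gives 37300 nM. Compound 2 `COc1ccc(Cn2cc(-c3ccc(O)cc3)c(-c3ccc(O)cc3)c2)cc1OC` gives 29200 nM. Compound 3 `COc1ccc(Cn2cc(-c3ccc(O)c(O)c3)c(-c3ccc(O)c(O)c3)c2)cc1` gives 8300 nM, the lowest number of the three, with its steps to compound 2 and to compound 1 both beyond the usual scatter, so it counts as the strongest inhibitor in this set.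

The change from compound 1 to compound 2 is small: methoxy in place of hydrogen on an aromatic carbon. It brought a 1.3-fold lower number from compound 1 to compound 2 (0.11 log units; within the scatter), which is no real movement.

Compound 4 `COc1ccc(Cn2cc(-c3ccc(O)c(O)c3)c(-c3ccc(O)c(O)c3)c2)cc1OC` is not yet measured. It arises from compound 3 by the same change: methoxy in place of hydrogen on an aromatic carbon. The place of the change is described in the same words for both pairs, so the change is the same, and it occurs in two pairs among the compounds shown. The difference between the core of compound 3 and the core of compound 1 is not broken down here.

For the measured compounds named here, with only one earlier example of this change, the expectation for compound 4 rests on that example alone, and the outcome is expected to be a step like the one seen before, namely a 1.3-fold lower number from compound 3 to compound 4 (0.11 log units; within the scatter). Compound 4 is therefore estimated at 6400 nM in this assay, with a likely range from 3000 nM to 14000 nM.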

Compound 4, half-maximal inhibitory concentration: 10500 nM
Compound 4: the middle estimate sits 1.6-fold (0.22 log units) below what was measured, within the range that was stated.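

In this assay, the step from 4-methoxyphenyl to 3,4-dimethoxyphenyl on the core of compound 3 gives a 1.3-fold higher number from compound 3 to compound 4 (0.10 log units; within the scatter), so the added methoxy brings no real movement on this core. Set beside the earlier example, the two steps agree, even though their printed directions are opposite: the same change on two cores in this assay, a 1.3-fold lower number (0.11 log units; within the scatter) from compound 1 to compound 2 and a 1.3-fold higher number (0.10 log units; within the scatter) from compound 3 to compound 4, 1.6-fold (0.21 log units) apart, within the scatter of two such steps. This shows that, across these two pairs, the change carried over from one core to the other as a step too small to read, but it does not show that the same would hold on any other core, at any other place on the benzyl arm, or in any other test.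

The compounds shown leave open whether a different group at this place, such as an ethoxy group, a longer chain, an amine or a carboxylic acid, would give a step beyond the scatter. For the compounds shown here, they also leave open how the difference between the core of compound 1 and the core of compound 3 breaks down, as no compound here carries the extra hydroxyl groups on only one of the two outer rings.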